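The source may report more compounds than this note shows. Statements on the series, on what has been measured and on what is new or still open speak of the compounds shown alone.

Measured in a functional assay on the whole organism with Mus musculus as the target; a higher number here means that more compound is needed for the effect, a lower number that less compound is needed:
- compound 1 `CNC(=O)Cn1c(-c2ccc(Cl)cc2)nc2cccnc21`: 12.5 mg/kg
- compound 2 `CCN(CC)C(=O)Cn1c(-c2ccc(Cl)cc2)nc2cccnc21`: 16 mg/kg
- compound 3 `O=C(Cn1c(-c2ccc(Cl)cc2)nc2cccnc21)N1CCCCC1`: 56.2 mg/kg

Compound 3 has the highest number of the three, so more of it is needed for the effect than of either other compound. Compound 4 `O=C(Cn1c(-c2ccc(Cl)cc2)nc2cccnc21)Nc1cccnc1` carries (pyridin-3-yl)amino in place of piperidin-1-yl on a carbonyl carbon.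

For the measured compounds named here, two measured steps bear on this change, as both involve piperidin-1-yl at that same place. They are a 4.5-fold higher number from compound 1 to compound 3 (0.65 log units; beyond the scatter) and a 3.5-fold higher number from compound 2 to compound 3 (0.55 log units; beyond the scatter), both modest but beyond the scatter. The remaining step, a 1.3-fold higher number from compound 1 to compound 2 (0.11 log units; within the scatter), stays within the scatter. Read backwards, the two larger steps suggest that losing piperidin-1-yl lowers the number. Neither of them brings in an aromatic ring, however, so this is only indirect evidence and the size remains uncertain.

The expected change is a 2.6-fold lower number from compound 3 to compound 4 (0.41 log units; beyond the scatter), a modest drop. For compound 4 the estimated value is 22 mg/kg, with an expected range from 7 mg/kg to 70 mg/kg.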

Compound 4, dose for half-maximal effect: 100 mg/kg
The estimate for compound 4 lay 4.5-fold (0.66 log units) below the measured number, and the stated range ends below it.
By their numbers in this assay, from the lowest: compounds 1 and 2 (each within the scatter of the next); then compounds 3 and 4 (each within the scatter of the next).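

In this assay an aromatic ring at this place, with (pyridin-3-yl)amino in place of piperidin-1-yl on the carbonyl carbon, gives a 1.8-fold higher number from compound 3 to compound 4 (0.25 log units; within the scatter) and so cannot be told apart from the saturated ring. Set against the groups without a ring, the same change shows a 6.3-fold higher number from compound 2 to compound 4 (0.80 log units; beyond the scatter) and an 8.0-fold higher number from compound 1 to compound 4 (0.90 log units; beyond the scatter), so among these four compounds both ring-bearing groups, saturated or aromatic, go with higher numbers than methylamino and diethylamino. Nothing measured here offers a reason for this pattern.

As far as these compounds go, it remains open whether the pyridine nitrogen or the amide hydrogen matters at all, a question that a plain phenylamino group would help to settle. The compounds shown also leave open where a smaller ring such as pyrrolidin-1-yl, or a morpholin-4-yl group, would fall.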